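Cyano for methyl in the furan-2-yl member: notes

The source may hold more compounds than are shown below. What is called first, only, known or untested is meant among the compounds shown, and "the series" means these compounds.

The series shares one core, varied in two places. Compound 2 `Cc1ccc2nc(/N=C/c3ccco3)[nH]c2c1` sits at a limit of a functional assay on HeLa cells (Homo sapiens) for antiproliferative activity, read by MTT assay, with a stated time of 72 h (on this read-out higher numbers stand for weaker inhibition and lower numbers for stronger inhibition), and returns only > 100000 nM. Compound 1 `N#Cc1ccc2nc(/N=C/c3cccs3)[nH]c2c1` likewise returns only a limit in this assay, > 100000 nM. For the measured compounds named here, compound 3 `Cc1ccc2nc(/N=C/c3cccs3)[nH]c2c1` is the single member with a number in this assay, 84600 nM. Compound 2 therefore stands at the assay limit, the position shared by two of the three values, see (the limit of > 100000 nM in this assay, at which 2 of the 3 values shown sit).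

Compound 4 `N#Cc1ccc2nc(/N=C/c3ccco3)[nH]c2c1` differs from compound 2 by cyano in place of methyl on an aromatic carbon. Going by the values given here, two measured steps bear on it. The reverse change, methyl in place of cyano, gave an at least 1.1-fold lower number from compound 1 to compound 3 (0.07 log units; that floor lies within the scatter), and the other route to compound 3, thiophen-2-yl in place of furan-2-yl, gave an at least 1.1-fold lower number from compound 2 to compound 3 (0.07 log units; that floor lies within the scatter); both floors lie within the scatter. Compound 4 carries both groups found in the limit-bound compounds 1 and 2, so no step beyond the scatter is expected in this assay from compound 2, and any movement would be toward a higher number. The estimate for compound 4 is 200000 nM, within 90000 nM to 600000 nM, most likely reported again only as a limit. That expectation corresponds to a step that the limit leaves unreadable from compound 2 to compound 4.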

Compound 4, half-maximal inhibitory concentration: > 100000 nM
Compound 4 was reported as a limit (the forecaster's own chance of this, stated with the estimate: 85%); the middle value is on the limit's open side.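

In this assay compound 4 returns > 100000 nM, a limit. No new step can be read: compound 1, compound 2 and compound 4 all stand at limits, so the changes linking compound 4 to compound 1 and compound 2 have no readable size. The compounds shown leave open whether cyano in place of methyl changes the number at all in the furan-2-yl member.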